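Acid chain to methylsulfonyl on a shared diaryl core

A few compounds are considered here, and "the series" means these few. Any claim that something is new, unique, unknown or untested is made for them only; others in the source may bear on it.

Compound 1 `CCC(CC)(c1ccc(OCC(O)CO)c(C)c1)c1ccc(OCC(O)C(C)(C)C)c(OCC(O)C(C)(C)C)c1`: 78%
Compound 2 `CCC(CC)(c1ccc(OCCCCCCC(=O)O)c(C)c1)c1ccc(OCC(O)C(C)(C)C)c(OCC(O)C(C)(C)C)c1`: "not active" (no number reported)

Of the compounds shown here, two have been measured. In an assay on cells for binding affinity to vitamin D3 receptor (Homo sapiens), read by fluorescence, tested at 1 uM (on this read-out higher numbers stand for more inhibition at the one concentration tested (going by the name of the read-out) and lower numbers for less inhibition), compound 1 gives 78%. In this assay compound 2 is reported as "not active" (no number reported), so no single number stands for compound 2; all that its entry shows is that it did not reach a reportable figure, and no sized comparison between compound 2 and compound 1 can be drawn from the two values.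

Compound 3 `CCC(CC)(c1ccc(OS(C)(=O)=O)c(C)c1)c1ccc(OCC(O)C(C)(C)C)c(OCC(O)C(C)(C)C)c1` differs from compound 2 in one place: methylsulfonyl in place of 6-carboxyhexyl on an oxygen on an aromatic ring. Within the data shown here, no step between two measured compounds exists for a change of this kind, so there is nothing in the data to say how large a move to expect in this assay. Among the measured compounds shown here, the only anchor is that compound 2 stands without a number, and a rise of moderate size, beyond the scatter, is expected rather than none, though a result that again falls short of a reportable figure remains quite possible.

Compound 3 is therefore expected to give about 30% in this assay, with a range from 0% to 70%.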

Compound 3, a percentage reported as inhibition, at one concentration (the size of the read-out at that concentration, not a potency): "not active" (no number reported)
For compound 3 the study gives words and no number; there is nothing to compare the estimate with.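

In this assay compound 2 and compound 3 both stand without a number, so no step can be read between them. Nothing shown here offers an explanation for this result. The compounds shown leave open whether 6-carboxyhexyl and methylsulfonyl on that oxygen differ at all on this read-out, as neither compound reached a reportable figure.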